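Chloro to trifluoromethyl on the shared core, plasma protein binding

A few compounds are considered here, and "the series" means these few. Any claim that something is new, unique, unknown or untested is made for them only; others in the source may bear on it.

Compound 1, `COc1ccc(F)cc1C1CCN(c2ccn3c(CC4CC4)nnc3c2Cl)CC1`: in an ADME assay on a cell-free system (plasma, Homo sapiens) for protein binding (on this read-out lower numbers stand for a smaller free fraction and higher numbers for a larger free fraction), compound 1 gives < 0.01, which is a limit of the assay.
Compound 2, `COc1c(C2CCN(c3ccn4c(CC5CC5)nnc4c3Cl)CC2)ccc(F)c1F`: in this assay compound 2 gives < 0.01, again a limit.
Compound 3, `COc1c(F)ccc(F)c1C1CCN(c2ccn3c(CC4CC4)nnc3c2Cl)CC1`: in this assay compound 3 gives < 0.01, also a limit.

Within the data shown here, compound 3 therefore stands at the limit shared by all three measured compounds, as the limit of < 0.01 in this assay, at which 3 of the 3 values shown sit, records; none of the measured values is a number. Among the measured compounds shown here, the steps a step that the two limits leave unreadable from compound 1 to compound 2, a step that the two limits leave unreadable from compound 1 to compound 3 and a step that the two limits leave unreadable from compound 2 to compound 3, each a change in the fluorine pattern of the aryl group on the saturated ring, cannot be sized, and they show only that every compound stays at the limit.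

Compound 4, `COc1c(F)ccc(F)c1C1CCN(c2ccn3c(CC4CC4)nnc3c2C(F)(F)F)CC1`, is not yet measured. It differs from compound 3 by trifluoromethyl in place of chloro on an aromatic carbon. For the measured compounds named here, no measured step touches this position, so the three measured steps bear on it only by showing that the whole series sits at the limit regardless of the aryl substitution. The expected step that the limit leaves unreadable from compound 3 to compound 4 is therefore taken as none beyond the scatter, with the result most likely a limit again. For compound 4 the estimate in this assay is 0.005, ranging from 0.002 to 0.012.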

Compound 4, unbound fraction: < 0.01
Compound 4: only a limit was reported (the forecaster's own chance of this, stated with the estimate: 85%); the middle value does not contradict the limit.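

Compound 3 and compound 4 both stand only as limits in this assay, so no step can be read for trifluoromethyl in place of chloro, and the series shares one limit: the limit of < 0.01 in this assay, at which 4 of the 4 values shown sit.

Left open are the actual unbound fractions of compound 1, compound 2, compound 3 and compound 4, and whether any change shown moves them.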